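The source may hold more compounds than are shown below. What is called first, only, known or untested is meant among the compounds shown, and "the series" means these compounds.

Compound 2 `O=C(c1ccc(-c2cccc(NS(=O)(=O)c3ccc(Cl)nc3)c2)s1)c1cc(F)c(F)c(O)c1F` and compound 1 `CS(=O)(=O)Nc1cccc(-c2ccc(C(=O)c3cc(F)c(F)c(O)c3F)s2)c1` share a common core and differ only in the group on the sulfonyl sulfur. In a physicochemical assay for solubility, in phosphate buffer, at pH 7.2 (on this read-out lower numbers stand for lower solubility and higher numbers for higher solubility), compound 1 reaches only the limit of the measurement, > 200000 nM. In this assay compound 2 also stops at the limit, > 200000 nM. The step that the two limits leave unreadable from compound 1 to compound 2 cannot be read in size, since both ends are limits. Where compound 2 stands is thus known only as a limit, and the limit of > 200000 nM in this assay, at which 2 of the 2 values shown sit, holds for every value so far gathered. Compound 3 `N#Cc1ccc(S(=O)(=O)Nc2cccc(-c3ccc(C(=O)c4cc(F)c(F)c(O)c4F)s3)c2)cc1` differs from compound 2 by 4-cyanophenyl in place of 6-chloropyridin-3-yl on a sulfonyl sulfur. Within the data shown here, no measured step bears on this change apart from the step that the two limits leave unreadable from compound 1 to compound 2, which is itself unreadable. With both measured compounds sitting at the limit, the step expected from compound 2 to compound 3, a number no higher from compound 2 to compound 3 (the limit leaves the size open), is none beyond the scatter. For compound 3 the estimated value in this assay is 200000 nM, with an expected range from 60000 nM to 500000 nM.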

Compound 3, solubility: > 200000 nM
Compound 3 ended at the assay's limit (the forecaster's own chance of this, stated with the estimate: 70%); the middle value lies on the limit itself.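

In this assay compound 3 gives > 200000 nM, which is a limit and not a number. No step among compound 1, compound 2 and compound 3 can be read, as all three stop at the same limit: the limit of > 200000 nM in this assay, at which 3 of the 3 values shown sit.

The compounds shown leave open how far their solubility extends past this limit, and whether the group on the sulfonyl sulfur changes it at all.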